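The source may report more compounds than this note shows. Statements on the series, on what has been measured and on what is new or still open speak of the compounds shown alone.

In a functional assay on HeLa cells (Homo sapiens) for inhibition, read by MTT assay, with a stated time of 4 days (on this read-out higher numbers stand for weaker inhibition and lower numbers for stronger inhibition), compound 3 `COc1cc(NC(C)CCCNC(=O)NNC(=O)NC(CO)(CO)CO)c2ncccc2c1` stands at > 250000 nM, which is a limit and not a number. Compound 1 `COc1cc(NC(C)CCCNC(=O)NNC(=O)NCCCCCO)c2ncccc2c1` gives >= 250000 nM, also a limit. Compound 2 `COc1cc(NC(C)CCCNC(=O)NNC(=O)Nc2ccc(Cl)c(C(F)(F)F)c2)c2ncccc2c1` is the only one of these with a true number, 17000 nM.

Compound 4 `COc1cc(NC(C)CCCNC(=O)NNC(=O)NCCCO)c2ncccc2c1` has 3-hydroxypropyl in place of 2-hydroxy-1,1-bis(hydroxymethyl)ethyl on an amide-type nitrogen.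

The nearest measured comparison, also between two hydroxy-bearing groups, is a step that the two limits leave unreadable from compound 1 to compound 3, and its size cannot be read. The two large steps, an at least 14-fold lower number from compound 1 to compound 2 (1.16 log units; beyond the scatter) and an at least 14-fold higher number from compound 2 to compound 3 (1.16 log units; beyond the scatter), both involve the 4-chloro-3-(trifluoromethyl)phenyl group of compound 2, which compound 4 lacks. They therefore say little about this change.

Compound 4 is expected to stay with compound 1 and compound 3 in this assay, with no step beyond the scatter in either direction. The expected step is an at least 1.0-fold lower number from compound 3 to compound 4 (0.03 log units; that floor lies within the scatter). For compound 4 the estimate is 230000 nM, with an expected range of 100000 nM to 400000 nM, and a report as a limit is considered likely.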

Compound 4, half-maximal inhibitory concentration: > 250000 nM
Compound 4: a limit, no number; the forecaster's own chance of this, stated with the estimate: 70%; at least 1.0-fold (0.03 log units) between middle value and limit.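

Compound 4 gives only a limit, so the hydroxy-bearing groups shown on this amide-type nitrogen now span 3-hydroxypropyl, 5-hydroxypentyl and 2-hydroxy-1,1-bis(hydroxymethyl)ethyl, and none yields a true number: the limit of > 250000 nM in this assay, at which 2 of the 4 values shown sit.

Replacing 4-chloro-3-(trifluoromethyl)phenyl with 3-hydroxypropyl gives an at least 14-fold higher number from compound 2 to compound 4 (1.16 log units; beyond the scatter), so compound 2 remains the only compound shown with a true number in this assay. The steps to compound 4 from compound 1 and from compound 3 cannot be read, as each joins two limits, and no order among these three hydroxy-bearing groups can be given.

From the compounds shown here alone, it remains open how a plain phenyl or an unbranched alkyl chain with no hydroxy would read on this nitrogen. Going by these compounds, the separate contributions of the chloro and trifluoromethyl groups of compound 2 also remain open.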